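Working notes: hydroxy in place of bromo

This account rests on a few compounds, and the source may have more. Where it says the series, first, only, none or still open, it means among the compounds named here.

Measured in a functional assay on U-937 cells (Homo sapiens) for cytotoxicity, read by MTT assay, with a stated time of 24 h; a higher number here means a weaker inhibitor, a lower number a stronger inhibitor:
- compound 1 `CN1CCN(CCCCCOc2c(Br)cc(Br)cc2Oc2ccc(Br)cc2Br)CC1`: 49.1 ug/mL
- compound 2 `BrCCCCCOc1c(Br)cc(Br)cc1Oc1ccc(Br)cc1Br`: 29.5 ug/mL
- compound 3 `BrCCOc1c(Br)cc(Br)cc1Oc1ccc(Br)cc1Br`: 32.5 ug/mL

Compound 3 at 32.5 ug/mL lies within the scatter of both other compounds, so it holds no separate place among them. Compound 4 `OCCOc1c(Br)cc(Br)cc1Oc1ccc(Br)cc1Br` carries hydroxy in place of bromo on a saturated chain carbon, two bonds along the chain from an oxygen on an aromatic ring. The nearest evidence is other changes on this chain: a 1.1-fold higher number from compound 2 to compound 3 (0.04 log units; within the scatter), a 1.5-fold lower number from compound 1 to compound 3 (0.18 log units; within the scatter) and a 1.7-fold lower number from compound 1 to compound 2 (0.22 log units; within the scatter). All stay within the scatter, but none places hydroxy on the chain, so direct precedent is lacking. In this assay no step beyond the scatter is therefore expected, in either direction. The estimated step is a 1.0-fold lower number from compound 3 to compound 4 (0.01 log units; within the scatter). The expected value for compound 4 is 32 ug/mL, with an estimated range of 16 ug/mL to 62 ug/mL.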

Compound 4, half-maximal inhibitory concentration: 34.5 ug/mL
Compound 4: middle estimate off by 1.1-fold (0.03 log units), on the low side; the measured number falls inside the stated range.
By their numbers in this assay, from the lowest: compounds 2, 3, 4 and 1 (each within the scatter of the next).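

In this assay, hydroxy in place of bromo at this chain position gives a 1.1-fold higher number from compound 3 to compound 4 (0.03 log units; within the scatter), the first sign that a hydrogen-bond donor can stand here without a step beyond the scatter. Compound 4 also stays within the scatter of the other two chain variants, with a 1.2-fold higher number from compound 2 to compound 4 (0.07 log units; within the scatter) and a 1.4-fold lower number from compound 1 to compound 4 (0.15 log units; within the scatter). No measurement is at hand that bears on this result.

Open, as far as these compounds go, is whether a carboxylic acid or a primary amine at this chain end would also stay within the scatter. Hydroxy on a longer chain is equally open.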